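Nitro-for-hydrogen step carried over to a second core

This account rests on a few compounds, and the source may have more. Where it says the series, first, only, none or still open, it means among the compounds named here.

Compound 1 `Cc1cc(NC(=O)c2ccc(Cl)cc2)ccc1NS(C)(=O)=O` and compound 2 `Cc1cc(NC(=O)c2ccc(Cl)c([N+](=O)[O-])c2)ccc1NS(C)(=O)=O` share one core; compound 3 `CCS(=O)(=O)Nc1ccc(NC(=O)c2ccc(Cl)cc2)cc1OC` and compound 4 `CCS(=O)(=O)Nc1ccc(NC(=O)c2ccc(Cl)c([N+](=O)[O-])c2)cc1OC` share another, and the difference between the two cores is not broken down here. In an ADME assay on HEK293 cells (Homo sapiens) for cytotoxicity, read by MTT assay, with a stated time of 48 h (on this read-out higher numbers stand for weaker inhibition and lower numbers for stronger inhibition), compound 1 gives 50300 nM and compound 2 gives 73100 nM. The change from the first of these to the second is nitro in place of hydrogen on an aromatic carbon and it produced a 1.5-fold higher number from compound 1 to compound 2 (0.16 log units; within the scatter), so the pair cannot be ordered against each other. In this assay compound 3 gives > 250000 nM, which is a limit of the assay and not a number. That value is the one described by the limit of > 250000 nM in this assay, at which 1 of the 3 values shown sits.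

Compound 4 has not yet been measured in this assay. The change leading to it is nitro in place of hydrogen on an aromatic carbon, the same change, at a place described in the same words, as the one already measured on the first core. The expected step for this assay is a step that the limit leaves unreadable from compound 3 to compound 4, and this expectation rests on the small size of a 1.5-fold higher number from compound 1 to compound 2 (0.16 log units; within the scatter) together with compound 3 already standing at the limit of > 250000 nM in this assay, at which 1 of the 3 values shown sits. Since a step of that size starting from a limit would most likely end at the same limit, compound 4 is expected to come back as a limit again rather than as a number. Compound 4 is estimated at 300000 nM, with the likely range running from 150000 nM to 600000 nM.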

Compound 4, half-maximal inhibitory concentration: 63700 nM
Compound 4: the middle estimate sits 4.7-fold (0.67 log units) above what was measured; measured number below the stated range.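

In this assay, nitro in place of hydrogen on an aromatic carbon gives an at least 3.9-fold lower number from compound 3 to compound 4 (0.59 log units; beyond the scatter), so the step measured on the core of compound 1 does not carry over unchanged to the core of compound 3: the same change on two cores in this assay, a 1.5-fold higher number (0.16 log units; within the scatter) from compound 1 to compound 2 and an at least 3.9-fold lower number (0.59 log units; beyond the scatter) from compound 3 to compound 4, at least 5.7-fold (0.75 log units) apart, beyond the scatter of two such steps

Compound 3 stands at a limit of the assay and not a number, so the new step gives only a smallest possible size, and its full size stays unknown: the limit of > 250000 nM in this assay, at which 1 of the 4 values shown sits.

The two cores differ in a way not broken down here, so the divergence cannot be tied to any single feature of either core, and one pair on each of two cores sets no rule for the wider series.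

Left open is whether another group in the same place, ortho to a chloro group, such as an amine or a nitrile, would follow the step seen on the core of compound 1 or the one seen on the core of compound 3. Also open, on these data alone, is how the nitro step would read on a further core, for instance one with a propyl chain in place of the ethyl chain of compound 3.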